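From Propoxy to Butylsulfanyl on a Shared Core

This account rests on a few compounds, and the source may have more. Where it says the series, first, only, none or still open, it means among the compounds named here.

Three compounds share one core and differ at a single ring position. In a functional assay (spleen, spleen) for activation, with Mus musculus as the target (on this read-out lower numbers stand for an effect already at smaller amounts and higher numbers for an effect only at larger amounts of compound), compound 1 `Nc1nc(N)c2nc(O)n(Cc3ccccc3)c2n1` gives 10 uM. Compound 2 `CNc1nc(N)c2nc(O)n(Cc3ccccc3)c2n1` gives 1 uM in this assay, and compound 3 `CCCOc1nc(N)c2nc(O)n(Cc3ccccc3)c2n1` gives 0.01 uM in this assay. Compound 3 thus stands at the lowest of the three numbers; the nearest is compound 2, and compound 1 lies furthest away. The measured steps are a 10-fold lower number from compound 1 to compound 2 (1.00 log units; beyond the scatter), a 1000-fold lower number from compound 1 to compound 3 (3.00 log units; beyond the scatter) and a 100-fold lower number from compound 2 to compound 3 (2.00 log units; beyond the scatter).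

Compound 4 `CCCCSc1nc(N)c2nc(O)n(Cc3ccccc3)c2n1` differs from compound 3 in one place: butylsulfanyl in place of propoxy on an aromatic carbon. Among the measured compounds shown here, no measured step exchanges one such group for another of the same kind; the two large steps into compound 3 show only that propoxy stands far apart from amino and methylamino at this position. Both propoxy and butylsulfanyl carry no hydrogen-bond donor and one hydrogen-bond acceptor. Compound 4 is expected to stay nearer to compound 3 than to compound 1 or compound 2. The expected step is a 3.0-fold higher number from compound 3 to compound 4 (0.48 log units; beyond the scatter), a small rise at the edge of the scatter. The estimate for compound 4 in this assay is 0.03 uM, with a range from 0.003 uM to 0.3 uM.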

Compound 4, minimum effective concentration: 0.01 uM
Compound 4: the middle estimate sits 3.0-fold (0.48 log units) above what was measured; measured number inside the range.
By their numbers in this assay, from the lowest: compounds 3 and 4 (each within the scatter of the next); then compound 2; then compound 1.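

In this assay the exchange of propoxy for butylsulfanyl gives no change at the digits printed from compound 3 to compound 4 (within the scatter), so at this position the chain can change its linking atom from oxygen to sulfur and its name from propoxy to butylsulfanyl without a step beyond the scatter. The large distance from the amino-bearing compounds is therefore not confined to propoxy: butylsulfanyl shows a 100-fold lower number from compound 2 to compound 4 (2.00 log units; beyond the scatter) and a 1000-fold lower number from compound 1 to compound 4 (3.00 log units; beyond the scatter), which match in size the steps already seen for propoxy. Nothing available explains why these two groups read alike in this assay or why both stand so far from amino and methylamino.

The linking atom and the chain change together in this single exchange, so the effect of each alone stays unresolved; butoxy or propylsulfanyl at the same position would separate them. Going by these compounds, it also remains open whether a longer chain such as hexylsulfanyl, or a propylamino group with its nitrogen link, would read with compound 3 and compound 4 or would instead fall nearer to compound 2.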